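The source may hold more compounds than are shown below. What is called first, only, known or untested is meant among the compounds shown, and "the series" means these compounds.

Notes on the series. Compound 1 `COc1c(Cl)ccc2c1CCC2c1ncc[nH]1` has been measured in a functional assay on CHO cells for agonist activity at Alpha-1D adrenergic receptor (Homo sapiens), read by FLIPR and calcium flux; a lower number here means that less compound is needed, a higher number that more compound is needed for the effect. In this assay compound 1 gives > 10000 nM, which is a limit of the assay and not a number. Compound 2 `Cn1cc(-c2cccc3c2CCC3c2ncc[nH]2)cn1` gives > 10000 nM in this assay, again a limit. Compound 3 `Cc1oncc1-c1cccc2c1CCC2c1ncc[nH]1` gives > 10000 nM in this assay, also a limit. The step that the two limits leave unreadable from compound 2 to compound 3 therefore cannot be read. All three values sit at the same point: the limit of > 10000 nM in this assay, at which 3 of the 3 values shown sit. Compound 1 stands at that limit together with the other two, so no ordering among the three can be drawn.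

Compound 4 `Clc1ccc2c(c1-c1cn[nH]c1)CCC2c1ncc[nH]1` has not yet been measured. It differs from compound 1 as follows: 1H-pyrazol-4-yl in place of methoxy on an aromatic carbon. Going by the values given here, no measured step bears directly on this change; the only step recorded is unreadable, and every value shown is a limit. The expectation for compound 4 rests on compound 1 sitting at > 10000 nM, a limit, and on (the limit of > 10000 nM in this assay, at which 3 of the 3 values shown sit). Compound 4 is therefore expected to give 15000 nM in this assay, with a range from 3000 nM to 60000 nM, most likely reported once more as a limit. The step that the limit leaves unreadable from compound 1 to compound 4 is the estimated consequence, and it is not expected to be distinguishable from none.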

Compound 4, half-maximal effective concentration: > 10000 nM
Compound 4: a limit, no number; the forecaster's own chance of this, stated with the estimate: 80%; the middle value is on the limit's open side.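

No step can be read between compound 1 and compound 4, since both values are limits and not numbers: the limit of > 10000 nM in this assay, at which 4 of the 4 values shown sit.

The compounds shown leave open which change on the shared core, if any, would give a readable value in this assay, and how these groups rank.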